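Amide substituent series on a shared core: notes toward compound 3

The compounds below may be only part of what the source reports. "The series", "measured", "known", "first", "only" and "open" are said of these compounds alone.

Two compounds of the shared core have been run in a functional assay on the whole organism for inhibition, with Rattus norvegicus as the target, read by cytopathic effect and paw edema, at a dose of 100 mg/kg by the oral route; on this read-out lower numbers stand for less inhibition and higher numbers for more inhibition at the one dose given (going by the name of the read-out). Compound 1, `O=C(NC1CCN(Cc2ccccc2)CC1)c1c(O)c2cccnc2n(-c2ccccc2)c1=O`, gives 1.2%. Compound 2, `O=C(NN1CCOCC1)c1c(O)c2cccnc2n(-c2ccccc2)c1=O`, gives -26.2%, the lowest of the two numbers; its nearest neighbour is compound 1, which stands higher by a margin beyond the scatter. Going by the values given here, no pair among the measured compounds differs in one place only, so no single step has been isolated so far.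

Compound 3, `Cc1cccc(NC(=O)c2c(O)c3cccnc3n(-c3ccccc3)c2=O)c1`, has not yet been measured. Relative to compound 2 it shows (3-methylphenyl in place of morpholin-4-yl on an amide-type nitrogen); the difference sits on an amide-type nitrogen whose other neighbour is the carbonyl carbon, and cut one bond further out it reads as (morpholin-4-yl)amino going to (3-methylphenyl)amino.

The measured compounds give no direct guide to this change. Compound 2 stands at -26.2%, while compound 1, with a different group on the amide nitrogen, stands at 1.2%. In this assay the expected step is a number 36.2 percentage points higher from compound 2 to compound 3 (beyond the scatter). For compound 3 the estimate in this assay is 10%, with a range from -15% to 35%.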

Compound 3, a percentage reported as inhibition, in the whole organism at one dose (the size of the read-out at that dose, not a potency): 4.5%
The estimate for compound 3 lay 5.5 percentage points above the measured number; the measured number falls inside the stated range.
By their numbers in this assay, from the lowest: compound 2; then compounds 1 and 3 (each within the scatter of the next).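

In this assay, the amide-type nitrogen whose other neighbour is the carbonyl carbon now has its first isolated single step: 3-methylphenyl in place of morpholin-4-yl gives a number 30.7 percentage points higher from compound 2 to compound 3 (beyond the scatter), a large move. Going by these compounds alone, the group on this nitrogen is therefore enough on its own to shift the read-out on the shared core, which could not be said while no single step had been isolated. Nothing measured on these compounds explains the step, so it stands here as an observation without a stated cause.

A single step cannot separate what the departure of morpholin-4-yl contributes from what the arrival of 3-methylphenyl contributes, and a percentage at one dose is not a potency. From the compounds shown here alone, it remains open how an unsubstituted phenyl, a phenyl carrying a carboxylic acid, or a longer alkyl chain ending in an amine would read on the same nitrogen, and whether the methyl group of 3-methylphenyl has any part in the step.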